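This account rests on a few compounds, and the source may have more. Where it says the series, first, only, none or still open, it means among the compounds named here.

In a functional assay on DU-145 cells (Homo sapiens) for cytotoxicity, read by MTT assay, with a stated time of 48 h (on this read-out higher numbers stand for weaker inhibition and lower numbers for stronger inhibition), compound 1 `Cc1ccc(S(=O)(=O)/N=C(/CCNC2=CC(=O)c3ccccc3C2=O)Nc2ccc(Cl)cc2)cc1` gives 32400 nM. Within the data shown here, compound 2 `Cc1ccc(S(=O)(=O)/N=C(/CCNC2=CC(=O)c3ccccc3C2=O)Nc2ccccc2[N+](=O)[O-])cc1` gives 7590 nM, the lower of the two numbers measured so far, and the only known step is a 4.3-fold lower number from compound 1 to compound 2 (0.63 log units; beyond the scatter). Compound 3 `Cc1ccc(S(=O)(=O)/N=C(/CCNC2=CC(=O)c3ccccc3C2=O)Nc2ccccc2I)cc1` differs from compound 2 by iodo in place of nitro on an aromatic carbon. Among the measured compounds shown here, no measured step exchanges one group on that ring for another, so the earlier step gives only a loose sense of how much a change here can matter, and a step no larger than the scatter is expected in either direction. Compound 3 is therefore estimated at 10000 nM, between 3000 nM and 35000 nM, a step of a 1.3-fold higher number from compound 2 to compound 3 (0.12 log units; within the scatter).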

Compound 3, half-maximal inhibitory concentration: 11700 nM
Beside the measured number, compound 3's estimate is 1.2-fold (0.07 log units) below it; measured number inside the range.
By their numbers in this assay, from the lowest: compounds 2 and 3 (each within the scatter of the next); then compound 1.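

In this assay, iodo in place of nitro gives a 1.5-fold higher number from compound 2 to compound 3 (0.19 log units; within the scatter), so at this place a single iodine atom and a three-atom nitro group, with its two hydrogen-bond acceptors, cannot be told apart. Compound 3 also shows a 2.8-fold lower number from compound 1 to compound 3 (0.44 log units; beyond the scatter), but that change alters both the halogen and where it sits on the ring. Nothing available explains either result. From the compounds shown here alone, whether an amine or a methoxy group at this place would give a similar number stays open. So does which part of the change from compound 1 to compound 3 matters.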